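This account rests on a few compounds, and the source may have more. Where it says the series, first, only, none or still open, it means among the compounds named here.

In a physicochemical assay for solubility, measured as kinetic solubility (on this read-out lower numbers stand for lower solubility and higher numbers for higher solubility), compound 1 `Cc1cnc(NC(=O)c2cc(Oc3ccc(S(=O)(=O)N(C)C)cc3)c3cn(C)nc3c2)cn1` gives 134000 nM, compound 2 `CNS(=O)(=O)c1ccc(Oc2cc(C(=O)Nc3cnc(C)cn3)cc3nn(C)cc23)cc1` gives 27000 nM, and compound 3 `CCn1cc2c(Oc3ccc(S(C)(=O)=O)cc3)cc(C(=O)Nc3cnc(C)cn3)cc2n1` gives 2100 nM, the lowest of the three numbers. Compound 4 `Cc1cnc(NC(=O)c2cc(Oc3ccc(S(C)(=O)=O)cc3)c3cn(CCO)nc3c2)cn1` differs from compound 3 by hydroxy in place of hydrogen on a saturated chain carbon, two bonds along the chain from an aromatic nitrogen: ethyl becomes 2-hydroxyethyl. For the measured compounds named here, no measured step covers this chain. Going by the values given here, the only single-place step available is a 5.0-fold lower number from compound 1 to compound 2 (0.70 log units; beyond the scatter), hydrogen in place of methyl on a sulfonamide nitrogen, which bears on size alone and only loosely. The expected step, toward a higher number and of similar modest size, is a 4.3-fold higher number from compound 3 to compound 4 (0.63 log units; beyond the scatter). The estimate for compound 4 is 9000 nM, with an expected range of 3000 nM to 30000 nM.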

Compound 4, solubility: 24400 nM
Estimate against measurement, compound 4: 2.7-fold (0.43 log units) below, within the range that was stated.
By their numbers in this assay, from the lowest: compound 3; then compounds 4 and 2 (each within the scatter of the next); then compound 1.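

In this assay, the ethyl chain of compound 3 proves responsive: one added oxygen, as hydroxy in place of hydrogen on a saturated chain carbon, two bonds along the chain from an aromatic nitrogen, gives a 12-fold higher number from compound 3 to compound 4 (1.07 log units; beyond the scatter). This is the first step shown at this position, and it is large. No measurement shown accounts for its size.

Open, on these data alone, is whether a longer chain ending in hydroxy, an amine or a carboxylic acid at the same place gives a step of similar size. Also open, as far as these compounds go, is whether the change holds with the sulfonamide of compound 1.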